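Adding a Cyano Group to the Most Efficacious Compound

The compounds below may be only part of what the source reports. "The series", "measured", "known", "first", "only" and "open" are said of these compounds alone.

Measured so far:
Compound 1, `COc1cc(CCC(=O)O)ccc1-c1ccc2c(C)nn(-c3ccccn3)c2c1` — in a functional assay on cells for agonist activity at Free fatty acid receptor 1 (Mus musculus), read by FLIPR and calcium flux, with a stated time of 5 min (on this read-out higher numbers stand for larger maximal responses and lower numbers for smaller maximal responses), compound 1 reaches 62%.
Compound 2, `O=C(O)CCc1ccc(-c2ccc3cnn(-c4ccccn4)c3c2)cc1` — in this assay compound 2 reaches 106%.

Compound 2 stands highest of the two numbers, and its gap to compound 1 lies well beyond the usual scatter of repeated measurements. For the measured compounds named here, compound 1 and compound 2 differ in more than one place, so the two values show only that compound 2 gives the larger maximal response.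

Compound 3, `N#Cc1nn(-c2ccccn2)c2cc(-c3ccc(CCC(=O)O)cc3)ccc12`, has not yet been measured. It differs from compound 2 in a single respect: cyano in place of hydrogen on an aromatic carbon. Going by the values given here, no comparable step between two measured compounds is available, so the effect of this change is an open question. Given that the parent, compound 2, already gives a near-complete response at 106%, there is little room for a rise, and a modest fall or no change beyond the scatter seems the most likely outcome.

Compound 3 is therefore expected to give about 95% in this assay, with a plausible range from 70% to 115%, meaning an estimated step of a number 11 percentage points lower from compound 2 to compound 3 (beyond the scatter).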

Compound 3, largest response reached (reported as efficacy), in percent of the reference or control that the assay uses: 124%
The estimate for compound 3 lay 29 percentage points below the measured number; the whole stated range lies below it.
By their numbers in this assay, from the lowest: compound 1; then compound 2; then compound 3.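

In this assay, for the compounds shown here, cyano in place of hydrogen on an aromatic carbon of the five-membered aromatic ring, two ring bonds from the ring atom that bears a pyridin-2-yl group, gives a number 18 percentage points higher from compound 2 to compound 3 (beyond the scatter) and is the first change here that can be read on its own. It shows that this carbon carries a group of 2 heavy atoms without any loss of maximal response, and that the already high response of compound 2, at 106% of the reference, was not a ceiling in this read-out. Nothing shown here accounts for the rise, so this single step records what happened without giving a reason for it.

The compounds shown leave open whether the gain belongs to cyano in particular or would also appear with a chlorine atom or an amide on the same carbon. They also leave open whether cyano at this position would raise the maximal response in the same way on a core that carries a methoxy group, as compound 1 does.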